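The source may report more compounds than this note shows. Statements on the series, on what has been measured and on what is new or still open speak of the compounds shown alone.

Working notes on the thiourea series.

Compound 1 `CCNC(=S)Nc1cccc(C(F)(F)F)c1` carries an ethyl group on one nitrogen of the shared core. In an ADME assay on BHK cells (Mesocricetus auratus) for cytotoxicity, read by MTT assay, with a stated time of 96 h (on this read-out lower numbers stand for higher toxicity in this test and higher numbers for lower toxicity in this test), compound 1 gives only a limit, > 100000 nM, not a number. The other two measured compounds carry a substituted phenyl ring on that nitrogen: compound 2 `Cc1ccc(NC(=S)Nc2cccc(C(F)(F)F)c2)cc1Cl` gives 10000 nM and compound 3 `Fc1ccc(NC(=S)Nc2cccc(C(F)(F)F)c2)cc1Cl` gives 10000 nM. For the measured compounds named here, the only measured step, no change at the digits printed from compound 2 to compound 3 (within the scatter), is within the scatter, so the two aryl compounds cannot be ranked against each other. Compound 1 stands apart from both only in that its value is a limit (the limit of > 100000 nM in this assay, at which 1 of the 3 values shown sits).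

Compound 4 `Fc1cccc(NC(=S)Nc2cccc(C(F)(F)F)c2)c1` is the unmeasured member; it differs from compound 1 by 3-fluorophenyl in place of ethyl on an amide-type nitrogen. Going by the values given here, no measured step covers this change directly; the nearest evidence is that both aryl-bearing compounds sit at the same number. The step from compound 1 to compound 4 is therefore expected to run toward higher toxicity, estimated as an at least 8.3-fold lower number from compound 1 to compound 4 (0.92 log units; beyond the scatter). Compound 4 is expected to give about 12000 nM, in the range 4000 nM to 40000 nM.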

Compound 4, half-maximal cytotoxic concentration: 9400 nM
Compound 4: the middle estimate sits 1.3-fold (0.11 log units) above what was measured; the measured number falls inside the stated range.
By their numbers in this assay, from the lowest: compounds 4, 2 and 3 (each within the scatter of the next). At a limit, above all of these: compound 1.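

In this assay, 3-fluorophenyl in place of ethyl on an amide-type nitrogen gives an at least 10-fold lower number from compound 1 to compound 4 (1.02 log units; beyond the scatter), so this position now has a directly read step, large and beyond the scatter. Compound 1 remains a limit, so the step has a floor and no exact size: the limit of > 100000 nM in this assay, at which 1 of the 4 values shown sits. Compound 4 also sits with compounds 2 and 3, each within the scatter of the next by number, so the ring patterns on these three phenyl groups cannot be told apart in this read-out.

From the compounds shown here alone, whether the step follows the aromatic ring or simply the larger group stays open: cyclohexyl or a longer chain such as hexyl on this nitrogen would separate the two. Also open, going by these compounds, is whether an amine or a carboxylic acid on the phenyl ring would move the number away from this cluster.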